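Dropping the 2-methoxyethoxy group from compound 2

The source may report more compounds than this note shows. Statements on the series, on what has been measured and on what is new or still open speak of the compounds shown alone.

Compound 2 (`COCCOc1cc(/C=C/c2ccc3ccccc3c2)ccc1OC`) reads > 5000 nM in a functional assay on HCT-116 cells (Homo sapiens) for inhibition (a higher number here means a weaker inhibitor, a lower number a stronger inhibitor), which is a limit and not a number. Compound 2 therefore stands at the limit of > 5000 nM in this assay, at which 1 of the 3 values shown sits, and any step from it has only a one-sided starting point. Compound 3 (`COCCOc1cc(/C=C\c2ccc3ccccc3c2)ccc1OC`) gives 2990 nM in this assay, and compound 1 (`COc1cc2ccc(CCc3ccc4ccccc4c3)cc2cc1O`) gives 3590 nM.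

Compound 4 (`COc1ccc(/C=C/c2ccc3ccccc3c2)cc1`) has hydrogen in place of 2-methoxyethoxy on an aromatic carbon, ortho to a methoxy group and meta to a large group: hydrogen in place of 2-methoxyethoxy on an aromatic carbon. Its double bond is drawn E, as in compound 2.

For the measured compounds named here, the one measured step is an at least 1.6-fold lower number from compound 2 to compound 3 (0.22 log units; that floor lies within the scatter). Going by the values given here, it concerns (the fact that compounds 2 and 3 differ only in the configuration as drawn), so it bears only indirectly on this change, and no measured pair removes or replaces the 2-methoxyethoxy group. With so little to go on, no step beyond the scatter is expected in this assay, and a second limit reading is about as likely as a number. Among the compounds with values here, the only numbers available as a guide are those of compound 3 at 2990 nM and compound 1 at 3590 nM, so a number, if one is reported, is expected to lie near these two values.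

The expected step is an at least 1.2-fold lower number from compound 2 to compound 4 (0.09 log units; that floor lies within the scatter). For compound 4 the estimate is 4000 nM, with an expected range of 1500 nM to 10000 nM.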

Compound 4, half-maximal inhibitory concentration: > 5000 nM
Compound 4 was reported as a limit; the forecaster's own chance of this, stated with the estimate: 50%; middle value at least 1.2-fold (0.09 log units) away from the limit.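

In this assay compound 4 reads > 5000 nM, a limit and not a number. Compound 2 reads > 5000 nM, also a limit, so the step between compound 2 and compound 4 cannot be read. The compounds shown leave open whether hydrogen in place of 2-methoxyethoxy on an aromatic carbon shifts the read-out in this assay at all.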